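Amide-end variation in a bis-sulfonyl piperidine series

This account rests on a few compounds, and the source may have more. Where it says the series, first, only, none or still open, it means among the compounds named here.

Measured so far:
compound 1, `CCN(CC)S(=O)(=O)c1ccc(S(=O)(=O)N2CCC[C@@H](C(=O)N3CCC(F)(F)CC3)C2)cc1`, 120 nM
compound 2, `O=C([C@@H]1CCCN(S(=O)(=O)c2ccc(S(=O)(=O)N3CC[C@H](O)C3)cc2)C1)N1CCC(F)(F)CC1`, 580 nM

Both numbers come from a functional assay on BXPC-3 cells (Homo sapiens) for inhibition, read by MTT assay, with a stated time of 7 days; a higher number here means a weaker inhibitor, a lower number a stronger inhibitor. Compound 1 holds the lowest of the two numbers; its nearest neighbour is compound 2, reached by the step of a 4.8-fold higher number from compound 1 to compound 2 (0.68 log units; beyond the scatter), which sits on the sulfonyl sulfur, not at the amide.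

The next compound, compound 3, `CCN(CC)S(=O)(=O)c1ccc(S(=O)(=O)N2CCC[C@@H](C(=O)N3CCOCC3)C2)cc1`, differs from compound 1 only at the other end of the shared core: morpholin-4-yl in place of 4,4-difluoropiperidin-1-yl on a carbonyl carbon. Among the compounds with values here, no measured step touches the carbonyl carbon, so the single step from compound 1 to compound 2 gives no direct guide to this change. With nothing pointing either way, the expected outcome is a step from compound 1 that stays within the usual scatter, or at most modest in either direction. The expected step is therefore a 1.7-fold higher number from compound 1 to compound 3 (0.22 log units; within the scatter). For compound 3 the estimate in this assay is 200 nM, with a range from 60 nM to 700 nM.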

Compound 3, half-maximal inhibitory concentration: 790 nM
Beside the measured number, compound 3's estimate is 4.0-fold (0.60 log units) below it; measured number outside the range, above it.
By their numbers in this assay, from the lowest: compound 1; then compounds 2 and 3 (each within the scatter of the next).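

In this assay, replacing 4,4-difluoropiperidin-1-yl with morpholin-4-yl on a carbonyl carbon gives a 6.6-fold higher number from compound 1 to compound 3 (0.82 log units; beyond the scatter), so the amide end of the shared core is sensitive to substitution. The earlier step showed this sensitivity only on the sulfonyl sulfur, and both ends now respond to change relative to compound 1. No available evidence bears on this step.

The change removes the two fluorine atoms and adds a ring oxygen together, so the compounds shown do not separate the contribution of each; an unsubstituted piperidin-1-yl amide would divide the step into those two parts. Also open, going by these compounds, is whether the changes on the sulfonyl sulfur and the carbonyl carbon would add up, as 3-hydroxypyrrolidin-1-yl and morpholin-4-yl have not been seen together in one compound here.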